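The compounds below may be only part of what the source reports. "The series", "measured", "known", "first", "only" and "open" are said of these compounds alone.

Compound 1 `CCOC(=O)C(=O)CC(=O)/C=C/c1cn(C=C(C)C)c2ccccc12` and compound 2 `CCOC(=O)C(=O)CC(=O)/C=C/c1cn(Cc2ccc(F)cc2)c2ccccc12` share one core and differ only at an aromatic nitrogen of that core, where compound 2 carries a 4-fluorobenzyl in place of the 2-methylprop-1-en-1-yl of compound 1. In an assay on isolated protein for inhibition of DNA nucleotidylexotransferase (Homo sapiens), read by scintillation counting, with a stated time of 10 min (a lower number here means a stronger inhibitor, a higher number a weaker inhibitor), compound 1 gives only a limit of the assay, > 40 uM. In this assay compound 2 likewise gives only a limit, > 40 uM. The step that the two limits leave unreadable from compound 1 to compound 2 therefore cannot be sized, both values stopping at the limit of > 40 uM in this assay, at which 2 of the 2 values shown sit. Among the compounds with values here, compound 2 thus stands at the limit with no number beneath it, and the one further value shown is also a limit.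

Compound 3 `CCOC(=O)C(=O)CC(=O)/C=C/c1cn(Cc2ccc(Cl)cc2)c2ccccc12` differs from compound 2 by chloro in place of fluoro on an aromatic carbon. Within the data shown here, no measured step touches this position; the only measured step, a step that the two limits leave unreadable from compound 1 to compound 2, concerns the group on the nitrogen and is itself unreadable. Because the limit of > 40 uM in this assay, at which 2 of the 2 values shown sit, holds both values shown, compound 3 is expected to rest there as well. The step that the limit leaves unreadable from compound 2 to compound 3 is expected to be none beyond the scatter. Compound 3 is estimated at 60 uM, within 20 uM to 200 uM.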

Compound 3, concentration for 50% inhibition: 40 uM
Compound 3: middle estimate off by 1.5-fold (0.18 log units), on the high side; the measured number falls inside the stated range.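

In this assay, within the data shown here, compound 3 gives 40 uM, the only actual number among the three compounds, so this position on the 4-chlorobenzyl now carries a reading rather than a limit. That number coincides with the value at which the limits stop, so neither a number no higher from compound 2 to compound 3 (the limit leaves the size open) nor a number no higher from compound 1 to compound 3 (the limit leaves the size open) can be read as a size, and chloro in place of fluoro on an aromatic carbon, para to a large group, cannot be said to change the result by more than the scatter. The series as a whole still lies at the edge of what this assay reads: the limit of > 40 uM in this assay, at which 2 of the 3 values shown sit.

The compounds shown leave open whether any other group at this position, such as bromo, methoxy or an amine, would give a number clearly lower than that of compound 3. They also leave open whether the shared core can give such a number at all, for instance with a carboxylic acid in place of the ethyl ester.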